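Fluorophenyl placement on the allyl-bearing diketopiperazylidene series

The compounds below may be only part of what the source reports. "The series", "measured", "known", "first", "only" and "open" are said of these compounds alone.

Measured compounds:
- compound 1, `C=CCn1c(=O)/c(=C\c2ccc(Cl)c(Cl)c2)[nH]c(=O)/c1=C\c1ccccc1`: "not active" (no number reported)
- compound 2, `C=CCn1c(=O)/c(=C\c2cccc(F)c2)[nH]c(=O)/c1=C\c1ccccc1OC`: 27200 nM
- compound 3, `COc1ccccc1/C=c1\c(=O)[nH]/c(=C/c2ccccc2Cl)c(=O)n1C`: 300 nM

In a functional assay on Huh-7 cells (Homo sapiens) for cytotoxicity, read by CCK-8 assay, with a stated time of 72 h (a lower number here means a stronger inhibitor, a higher number a weaker inhibitor), compound 2 gives 27200 nM, the highest of the two numbers reported; compound 1 is reported without a number. For the measured compounds named here, compound 3 stands far lower at 300 nM, but compound 3 also differs from compound 2 in more than one place, so no single step links them.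

Compound 4, `C=CCn1c(=O)/c(=C\c2ccccc2F)[nH]c(=O)/c1=C\c1ccccc1OC`, is not yet measured. It differs from compound 2 by 2-fluorophenyl in place of 3-fluorophenyl on a double-bonded chain carbon bound to an aromatic carbon. Going by the values given here, with no measured pair isolating this change, the direction is read from compound 3, which carries a 2-chlorophenyl and gives 300 nM; that comparison is confounded and cannot fix the size. A modest step towards a lower number is expected, a 2.7-fold lower number from compound 2 to compound 4 (0.43 log units; beyond the scatter), not far beyond the scatter. In this assay compound 4 is estimated at 10000 nM, with a range from 3000 nM to 30000 nM.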

Compound 4, half-maximal inhibitory concentration: 31300 nM
For compound 4 the middle estimate is 3.1-fold (0.50 log units) below the measured one; measured number above the stated range.
By their numbers in this assay, from the lowest: compound 3; then compounds 2 and 4 (each within the scatter of the next).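

In this assay, for the compounds shown here, the exchange of 3-fluorophenyl for 2-fluorophenyl on a double-bonded chain carbon bound to an aromatic carbon gives a 1.2-fold higher number from compound 2 to compound 4 (0.06 log units; within the scatter), the first single-place comparison. With the rest of the structure held constant, these two fluorine placements are not separated in this assay, and a fluorophenyl at this place gives no sign of a low number in either placement. No measurement available here bears on the reason for this result.

Going by these compounds alone, no single step connects compound 3, at 300 nM, to compound 2 or compound 4, so it remains open which of its structural differences goes with that value. Also open, as far as these compounds go, is how a nitrile or a dimethylamino group on this phenyl would read.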